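The source may report more compounds than this note shows. Statements on the series, on what has been measured and on what is new or still open speak of the compounds shown alone.

In a functional assay on MGC-803 cells (Homo sapiens) for antiproliferative activity, read by MTT assay, with a stated time of 48 h (on this read-out higher numbers stand for weaker inhibition and lower numbers for stronger inhibition), compound 1 (`COc1ccc(CN(C(=O)CSc2nc3ccccc3s2)c2cc(OC)c(OC)c(OC)c2)cc1`) gives 163 nM and compound 2 (`COc1ccc(CN(C(=O)CSc2nc3ccccc3s2)c2cc(OC)c(OC)c(OC)c2)cc1OC`) gives 34100 nM. Compound 3 (`COc1cc(N(Cc2ccc(Cl)cc2)C(=O)CSc2nc3ccccc3s2)cc(OC)c1OC`) is recorded at > 80000 nM, which is a limit of the assay and not a number. Compound 4 (`COc1ccc(CN(C(=O)CSc2nc3ccccc3s2)c2cc(OC)c(OC)c(OC)c2)cc1N`) differs from it by 3-amino-4-methoxyphenyl in place of 4-chlorophenyl on a saturated chain carbon bound to an amide-type nitrogen, with 3-amino-4-methoxyphenyl in place of 4-chlorophenyl on a saturated chain carbon bound to an amide-type nitrogen.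

Within the data shown here, three measured steps bear on this change. Chloro in place of methoxy produced an at least 490-fold higher number from compound 1 to compound 3 (2.69 log units; beyond the scatter), and compound 4 restores that methoxy, which argues for a large move towards stronger inhibition. A methoxy in place of hydrogen, however, produced a 210-fold higher number from compound 1 to compound 2 (2.32 log units; beyond the scatter), so an extra group on compound 1 can be costly, and compound 4 also carries an extra group, an amino group. The step of an at least 2.3-fold higher number from compound 2 to compound 3 (0.37 log units; beyond the scatter) leaves compound 2 as the nearer neighbour on the weak side.

A large fall in the number is therefore expected, with a wide margin of doubt: an at least 100-fold lower number from compound 3 to compound 4 (2.00 log units; beyond the scatter). The estimate for compound 4 is 800 nM, within an expected range of 40 nM to 30000 nM.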

Compound 4, half-maximal inhibitory concentration: 84 nM
Compound 4: middle estimate off by 9.5-fold (0.98 log units), on the high side, and the stated range covers the measured number.
By their numbers in this assay, from the lowest: compounds 4 and 1 (each within the scatter of the next); then compound 2. At a limit, above all of these: compound 3.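

In this assay, an added group on this ring is not costly in every case: amino in place of hydrogen gives a 1.9-fold lower number from compound 1 to compound 4 (0.29 log units; within the scatter), while amino in place of methoxy gives a 410-fold lower number from compound 2 to compound 4 (2.61 log units; beyond the scatter), so the large loss in compound 2 goes with its added methoxy and not with the amino of compound 4. Replacing 4-chlorophenyl with 3-amino-4-methoxyphenyl on a saturated chain carbon bound to an amide-type nitrogen gives an at least 950-fold lower number from compound 3 to compound 4 (2.97 log units; beyond the scatter). That step starts from a limit of the assay and not a number, recorded for compound 3: the limit of > 80000 nM in this assay, at which 1 of the 4 values shown sits.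

The compounds shown leave open whether the amino group can be replaced by a hydroxyl or an acetamido group with the same result. They also leave open how 3-aminophenyl, without the methoxy, would compare.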